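Chain lengthening and stability in a carbamate series

The compounds below may be only part of what the source reports. "The series", "measured", "known", "first", "only" and "open" are said of these compounds alone.

Measured so far:
compound 1 `CCCCCNC(=O)Oc1ccc(Cl)cc1C(=O)Nc1cccc(Cl)c1`: 64 h
compound 2 `CCCCCCNC(=O)Oc1ccc(Cl)cc1C(=O)Nc1cccc(Cl)c1`: 64 h
compound 3 `CCCCCCCCNC(=O)Oc1ccc(Cl)cc1C(=O)Nc1ccc(Cl)cc1`: 64 h

Compounds 1 and 2 share a core and differ by methyl in place of hydrogen on a saturated chain carbon, five bonds along the chain from an amide-type nitrogen. In an ADME assay for metabolic stability, read by HPLC, at pH 7 (a higher number here means that the compound lasts longer, a lower number that the compound disappears faster), this change gave no change at the digits printed from compound 1 to compound 2 (within the scatter). Compound 3 carries a core whose difference from that of compound 1 is not broken down here; in this assay compound 3 sits level with compounds 1 and 2, within the scatter.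

Compound 4 `CCCCCCCCCNC(=O)Oc1ccc(Cl)cc1C(=O)Nc1ccc(Cl)cc1` has not yet been measured. It differs from compound 3 by methyl in place of hydrogen on a saturated chain carbon, eight bonds along the chain from an amide-type nitrogen. For the measured compounds named here, this is the same kind of change as the one from compound 1 to compound 2, though the added methyl sits eight bonds, not five, along the chain from the amide-type nitrogen. Because no change at the digits printed from compound 1 to compound 2 (within the scatter), the step of no change at the digits printed from compound 3 to compound 4 (within the scatter) is expected to be similarly flat. Compound 4 is therefore estimated at 64 h, likely between 32 h and 128 h.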

Compound 4, half-life: 64 h
The estimate for compound 4 equals the measured number at the digits printed; low and high end bracket the measured number.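

In this assay, adding the methyl gave no change at the digits printed from compound 3 to compound 4 (within the scatter). Set beside the earlier step, the two results agree: the same change on two cores in this assay, no change at the digits printed (within the scatter) from compound 1 to compound 2 and no change at the digits printed (within the scatter) from compound 3 to compound 4, 1.0-fold (0.00 log units) apart, within the scatter of two such steps. On these two cores, then, the change carries over as a flat step, with the methyl placed five bonds along the chain on one and eight bonds along on the other, but two cases cannot show that it would stay flat on a different core, nor why it is flat here.

The compounds shown leave open whether a much longer chain would also stay level in this assay. They also leave open what an amine or a carboxylic acid on the chain would do.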